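This account rests on a few compounds, and the source may have more. Where it says the series, first, only, none or still open, it means among the compounds named here.

Three compounds were measured in a functional assay on PC-12 cells (Rattus norvegicus) for cytotoxicity, read by MTT assay, with stated times of 3 h and 2 h, tested at 10 uM; a higher number here means a stronger effect of the compound at the concentration tested, a lower number a weaker effect. Compound 1 `O=C(CCCCC1CCSS1)NCc1cn(CCCOc2ccc3cc(-c4ccccc4)c(=O)oc3c2)nn1` gives 29.1%. Compound 2 `COc1ccc(-c2cc3ccc(OCCCn4cc(CNC(=O)CCCCC5CCSS5)nn4)cc3oc2=O)cc1` gives 57.6%; it differs from compound 1 by methoxy in place of hydrogen on an aromatic carbon, and that change gave a number 28.5 percentage points higher from compound 1 to compound 2 (beyond the scatter). Compound 3 `COc1ccc(-c2cc3ccc(OCCCCCn4cc(CNC(=O)CCCCC5CCSS5)nn4)cc3oc2=O)cc1` gives 45.5%; how its core differs from that of compound 1 is not broken down here.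

Compound 4 `COc1ccc(-c2cc3ccc(OCCCCCn4cc(CNC(=O)CCCCC5CCSS5)nn4)cc3oc2=O)cc1OC` is not yet measured. It differs from compound 3 by methoxy in place of hydrogen on an aromatic carbon, the same kind of change as that from compound 1 to compound 2, though the place differs: there the new group sat para to a large group, here it sits ortho to a methoxy group and meta to a large group. Because a number 28.5 percentage points higher from compound 1 to compound 2 (beyond the scatter) was a modest rise, a smaller rise is expected from compound 3 to compound 4, namely a number 9.5 percentage points higher from compound 3 to compound 4 (within the scatter). Compound 4 is therefore estimated at 55%, between 35% and 75%.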

Compound 4, a percentage reported as activity, at one concentration (the size of the read-out at that concentration, not a potency): 50.5%
Compound 4: the middle estimate sits 4.5 percentage points above what was measured, and the stated range covers the measured number.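

Placing a second methoxy on the aromatic ring, which turns 4-methoxyphenyl into 3,4-dimethoxyphenyl, gave a number 5 percentage points higher from compound 3 to compound 4 (within the scatter) in this assay. Adding a methoxy group therefore does not bring a fixed gain from one core to another in this series: the same change on two cores in this assay, a number 28.5 percentage points higher (beyond the scatter) from compound 1 to compound 2 and a number 5 percentage points higher (within the scatter) from compound 3 to compound 4, 23.5 percentage points apart, beyond the scatter of two such steps

These two steps do not show whether the gap follows from the core or from the place of the new group, as both differ at once. The compounds shown leave open how an amine, a hydroxyl or a carboxylic acid in place of the new methoxy would read in this assay. They also leave open whether a chain longer than that of compound 3 would alter the size of the step.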